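Working notes: fluoro in place of ethoxy, compound 3

The source may hold more compounds than are shown below. What is called first, only, known or untested is meant among the compounds shown, and "the series" means these compounds.

Compound 1 `CCOC(=O)CCCCCOc1cccc(CN(C(=O)c2ccc(-c3cccc(C(C)=O)c3)cc2)C(C)C)c1`: > 26000 nM, a limit
Compound 2 `CCOC(=O)CCCCCOc1cccc(CN(C(=O)c2ccc(-c3cccc(OCC)c3)cc2)C(C)C)c1`: > 22300 nM, a limit

Both entries come from an ADME assay on BJ cells (Homo sapiens) for cytotoxicity, read by CellTiter-Glo and resazurin assay, with a stated time of 72 h (a lower number here means that less compound is needed, a higher number that more compound is needed for the effect), and neither is a number. Where compound 2 stands is therefore known only as the limit > 22300 nM. Among the measured compounds shown here, the one measured step is a step that the two limits leave unreadable from compound 1 to compound 2, with ethoxy in place of acetyl on an aromatic carbon, so no size carries over from it.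

Compound 3 `CCOC(=O)CCCCCOc1cccc(CN(C(=O)c2ccc(-c3cccc(F)c3)cc2)C(C)C)c1` has fluoro in place of ethoxy on an aromatic carbon, meta to a large group: fluoro in place of ethoxy on an aromatic carbon. The same difference reads 3-ethoxyphenyl to 3-fluorophenyl. In this assay the expectation rests on compound 2, whose > 22300 nM is a limit. The expected step is a step that the limit leaves unreadable from compound 2 to compound 3, none beyond the scatter. Compound 3 is estimated at 25000 nM, with an expected range of 11000 nM to 50000 nM, and another limit is the likelier report.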

Compound 3, half-maximal effective concentration: > 26000 nM
Compound 3: only a limit was reported (the forecaster's own chance of this, stated with the estimate: 75%); at least 1.0-fold (0.01 log units) between middle value and limit.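

In this assay compound 3 gives > 26000 nM, a limit. Compound 2 gives > 22300 nM, also a limit. Among the compounds shown here, no step among compound 1, compound 2 and compound 3 can be read. As far as these compounds go, what stays open is whether acetyl, ethoxy and fluoro differ at all in this assay.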